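Compound 3 Gains a Methyl: What Half-Life to Expect

A few compounds are considered here, and "the series" means these few. Any claim that something is new, unique, unknown or untested is made for them only; others in the source may bear on it.

Compound 3 `O=C(NCc1ccccc1)N1C(=O)c2ccccc2S1(=O)=O` stands highest of the three measured compounds in a physicochemical assay for pharmacokinetics (a higher number here means that the compound lasts longer, a lower number that the compound disappears faster), at 1.02 h. Compound 2 `O=C(NCc1cccc(Br)c1)N1C(=O)c2ccccc2S1(=O)=O` gives 0.492 h and compound 1 `O=C(NCc1ccccc1Br)N1C(=O)c2ccccc2S1(=O)=O` gives 0.253 h. These two carry bromo where compound 3 has hydrogen, and the move from 2-bromophenyl to 3-bromophenyl is a 1.9-fold higher number from compound 1 to compound 2 (0.29 log units; within the scatter).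

Compound 4 `Cc1ccccc1CNC(=O)N1C(=O)c2ccccc2S1(=O)=O` keeps the core of compound 3 and differs in one place: methyl in place of hydrogen on an aromatic carbon. This is methyl in place of hydrogen on an aromatic carbon, so phenyl becomes 2-methylphenyl.

Only the two bromo steps bear on this change, and they have to be read backwards. Hydrogen in place of bromo gives a 4.0-fold higher number from compound 1 to compound 3 (0.61 log units; beyond the scatter) and also a 2.1-fold higher number from compound 2 to compound 3 (0.32 log units; beyond the scatter). Both steps are modest, and in both the compound without the added group has the higher number. Among the measured compounds shown here, the closer parallel is the 2-bromophenyl of compound 1, but no methyl compound has been measured, so bromo is only a loose guide. A modest drop is therefore expected rather than no change, probably smaller than the drop seen with compound 1. The expected step is a 2.3-fold lower number from compound 3 to compound 4 (0.36 log units; beyond the scatter). For compound 4 the estimated half-life is 0.45 h, within an expected range from 0.2 h to 1 h.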

Compound 4, half-life: 0.792 h
Compound 4: middle estimate off by 1.8-fold (0.25 log units), on the low side; the measured number falls inside the stated range.
By their numbers in this assay, from the lowest: compounds 1, 2, 4 and 3 (each within the scatter of the next, the first and the last beyond it).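

In this assay, methyl in place of hydrogen on an aromatic carbon, ortho to a large group, gives a 1.3-fold lower number from compound 3 to compound 4 (0.11 log units; within the scatter), so this added group leaves no readable mark on the half-life. The identity of the group in this place does matter, as methyl in place of bromo gives a 3.1-fold higher number from compound 1 to compound 4 (0.50 log units; beyond the scatter), which shows that the low number of the 2-bromophenyl does not carry over to every group put there. Against the other bromo compound, 2-methylphenyl in place of 3-bromophenyl gives a 1.6-fold higher number from compound 2 to compound 4 (0.21 log units; within the scatter), so these two substituted phenyls cannot be told apart in this assay, even though only the 3-bromophenyl lies beyond the scatter from the unsubstituted phenyl.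

Nothing in the data shown gives a reason for any of these steps. As far as these compounds go, whether ethyl, methoxy or an amine in this same place would stay as close to compound 3 as methyl does, or would fall towards compound 1, remains open.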